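The compounds below may be only part of what the source reports. "The series", "measured", "known", "first", "only" and "open" are said of these compounds alone.

Series notes. Compound 1 `O=C(O)c1ccc(CN2CCC[C@H](OCc3cc(Cl)cc(Cl)c3)[C@@H]2c2ccccc2)s1` gives 76000 nM in an assay on isolated protein for activation of cGMP-dependent protein kinase 1 (Homo sapiens), read by ADP-Glo, with stated times of 120 min and 40 min; on this read-out lower numbers stand for an effect already at smaller amounts and higher numbers for an effect only at larger amounts of compound. Compound 3 `Clc1cc(Cl)cc(CO[C@H]2CCCN(Cc3ncc[nH]3)[C@H]2c2ccccc2)c1` gives 47000 nM, and compound 2 `OC[C@@H](O[C@H]1CCCN(Cc2ncc[nH]2)[C@H]1c1ccccc1)c1cc(Cl)cc(Cl)c1` gives 7000 nM, the lowest number of the three. Compound 4 `O=C(O)c1ccc2c(CN3CCC[C@H](O[C@H](CO)c4cc(Cl)cc(Cl)c4)[C@@H]3c3ccccc3)c[nH]c2c1` is not yet measured; relative to compound 2 the change is 6-carboxy-1H-indol-3-yl in place of 1H-imidazol-2-yl on a saturated chain carbon bound to an amine nitrogen in a ring. The step that bears on this is a 1.6-fold lower number from compound 1 to compound 3 (0.21 log units; within the scatter), a swap of the group on the same chain carbon that stayed within the scatter. The other shown step, a 6.7-fold higher number from compound 2 to compound 3 (0.83 log units; beyond the scatter), concerns the hydroxymethyl, which compound 4 keeps. Since a swap at this position has so far been indifferent, the expected step for compound 4 is no change at the digits printed from compound 2 to compound 4 (within the scatter). For compound 4 the estimate in this assay is 7000 nM, with a range from 2500 nM to 20000 nM.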

Compound 4, half-maximal effective concentration: 22000 nM
Beside the measured number, compound 4's estimate is 3.1-fold (0.50 log units) below it; the measured number lies above the stated range.
By their numbers in this assay, from the lowest: compound 2; then compound 4; then compounds 3 and 1 (each within the scatter of the next).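

In this assay this place is no longer indifferent to a swap: with the hydroxymethyl kept, 6-carboxy-1H-indol-3-yl in place of 1H-imidazol-2-yl gives a 3.1-fold higher number from compound 2 to compound 4 (0.50 log units; beyond the scatter) on a saturated chain carbon bound to an amine nitrogen in a ring. The earlier swap here, a 1.6-fold lower number from compound 1 to compound 3 (0.21 log units; within the scatter) and without the hydroxymethyl, involved a different pair of groups. No measurement shown accounts for the new step.
From the compounds shown here alone, whether the step follows the carboxylic acid or the larger aromatic group stays open. A plain 1H-indol-3-yl without the carboxylic acid would separate the two, and an amine at this place is also absent from the compounds shown.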